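Trading phenoxy for hydroxy on the weakest compound

This account rests on a few compounds, and the source may have more. Where it says the series, first, only, none or still open, it means among the compounds named here.

Measured so far in a functional assay on HL-60 cells (Homo sapiens) for inhibition, read by resazurin assay, with a stated time of 72 h; a higher number here means a weaker inhibitor, a lower number a stronger inhibitor:
compound 1 `COc1cc(N2C(=O)CC2c2ccc(SC)cc2)cc(OC)c1OC`: 69 nM
compound 2 `C=CC1C(=O)N(c2cc(OC)c(OC)c(OC)c2)C1c1ccc(SC)cc1`: 61 nM
compound 3 `COc1cc(N2C(=O)C(Oc3ccccc3)C2c2ccc(SC)cc2)cc(OC)c1OC`: 388 nM

Compound 3 has the highest number of the three, which makes it the weakest inhibitor here. The next compound, compound 4 `COc1cc(N2C(=O)C(O)C2c2ccc(SC)cc2)cc(OC)c1OC`, keeps the shared core and changes one group: hydrogen in place of phenyl on an oxygen on a saturated carbon, so phenoxy becomes hydroxy (hydrogen in place of phenyl on an oxygen on a saturated carbon).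

Within the data shown here, no hydroxy compound has been measured yet, so the guidance is indirect. Phenoxy in place of hydrogen gave a modest loss, a 5.6-fold higher number from compound 1 to compound 3 (0.75 log units; beyond the scatter). Phenoxy in place of vinyl gave a similar loss, a 6.4-fold higher number from compound 2 to compound 3 (0.80 log units; beyond the scatter). Vinyl in place of hydrogen made no real difference, a 1.1-fold lower number from compound 1 to compound 2 (0.05 log units; within the scatter). Only compound 3, at 388 nM, stands apart, so losing the phenyl is expected to regain much of that gap.

The expected change in this assay is a modest one towards a stronger inhibitor, a 3.5-fold lower number from compound 3 to compound 4 (0.55 log units; beyond the scatter). Compound 4 is estimated at 110 nM, with an expected range of 35 nM to 350 nM.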

Compound 4, half-maximal inhibitory concentration: 15 nM
For compound 4 the middle estimate is 7.3-fold (0.87 log units) above the measured one; measured number below the stated range.
By their numbers in this assay, from the lowest: compound 4; then compounds 2 and 1 (each within the scatter of the next); then compound 3.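

In this assay, among these compounds, the earlier compounds showed only that this saturated ring carbon could carry vinyl with no real change and phenoxy at a cost, whereas hydroxy is the first group here to give a clear gain over both hydrogen (a 4.6-fold lower number from compound 1 to compound 4 (0.66 log units; beyond the scatter)) and vinyl (a 4.1-fold lower number from compound 2 to compound 4 (0.61 log units; beyond the scatter)). The oxygen stays in place while the phenyl leaves (a 26-fold lower number from compound 3 to compound 4 (1.41 log units; beyond the scatter)), so the loss seen with phenoxy goes with the phenyl and not with having an oxygen on this carbon. Nothing available explains why hydroxy does so well.

The compounds shown leave open whether an amine or a fluorine on the same carbon would match hydroxy. They also leave open how a longer chain on the oxygen, such as ethoxy, would compare with hydroxy and phenoxy.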